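From compound 3 to compound 4: one ring exchanged

The source may hold more compounds than are shown below. What is called first, only, known or untested is meant among the compounds shown, and "the series" means these compounds.

Measured in a physicochemical assay for solubility; a lower number here means a less soluble compound, a higher number a more soluble compound:
Compound 1 `O=S(=O)(Nc1nccs1)c1ccc2c(c1)OCC[C@@H]2c1ccc(C(F)(F)F)cc1-c1ccc(F)cc1` gives 39000 nM
Compound 2 `Cc1nc(-c2cc(C(F)(F)F)ccc2[C@H]2CCOc3cc(S(=O)(=O)Nc4nccs4)ccc32)co1` gives 61000 nM
Compound 3 `O=S(=O)(Nc1nccs1)c1ccc2c(c1)OCC[C@@H]2c1ccc(C(F)(F)F)cc1-c1ccc(F)cn1` gives 7000 nM

Compound 3 stands lowest of the three, with both other compounds beyond the scatter from it. Compound 4 `O=S(=O)(Nc1nccs1)c1ccc2c(c1)OCC[C@@H]2c1ccc(C(F)(F)F)cc1-n1ccnn1` differs from it in one place: 1H-1,2,3-triazol-1-yl in place of 5-fluoropyridin-2-yl on an aromatic carbon. For the measured compounds named here, two measured steps bear on this, both modest and both ending at the 5-fluoropyridin-2-yl group (a 5.6-fold lower number from compound 1 to compound 3 (0.75 log units; beyond the scatter); an 8.7-fold lower number from compound 2 to compound 3 (0.94 log units; beyond the scatter)). The step of a 1.6-fold higher number from compound 1 to compound 2 (0.19 log units; within the scatter) stays within the scatter. Leaving that group is therefore expected to raise the number in this assay by a similar size, although no 1H-1,2,3-triazol-1-yl compound has yet been measured. A modest rise is expected (a 3.6-fold higher number from compound 3 to compound 4 (0.55 log units; beyond the scatter)). The estimate for compound 4 is 25000 nM (expected range 7000 nM to 80000 nM).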

Compound 4, solubility: 171000 nM
The estimate for compound 4 lay 6.8-fold (0.84 log units) below the measured number; the whole stated range lies below it.
By their numbers in this assay, from the lowest: compound 3; then compounds 1 and 2 (each within the scatter of the next); then compound 4.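

The 1H-1,2,3-triazol-1-yl group places compound 4 highest of the four in this assay, clear of the 5-fluoropyridin-2-yl group (a 24-fold higher number from compound 3 to compound 4 (1.39 log units; beyond the scatter)), the 2-methyl-1,3-oxazol-4-yl group (a 2.8-fold higher number from compound 2 to compound 4 (0.45 log units; beyond the scatter)) and the 4-fluorophenyl group (a 4.4-fold higher number from compound 1 to compound 4 (0.64 log units; beyond the scatter)). The earlier compounds shown here therefore did not mark the upper end at this position, and this ring exchange moves the number further than any earlier step. Nothing available explains the size of this rise. On these data alone, it remains open whether the rise is particular to this triazole or would recur with another five-membered aromatic ring, and how an amine or a carboxylic acid at this position would compare.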